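Swapping Phenyl for Pyridine on the Amide of Compound 3

The source may report more compounds than this note shows. Statements on the series, on what has been measured and on what is new or still open speak of the compounds shown alone.

Of the compounds shown here, three have been measured in an assay on CHO cells for positive allosteric modulation of metabotropic glutamate receptor 5 (Homo sapiens), read by FLIPR; a lower number here means that less compound is needed, a higher number that more compound is needed for the effect. Compound 1 `COc1ccc2c(c1OC)C(=O)N(Cc1cc(Br)ccc1NC(=O)c1ccccn1)C2=O` reaches only a limit of the assay, > 100000 nM. Compound 2 `O=C(CCc1cc(Cl)ccc1NC(=O)c1ccccn1)c1ccccc1` gives a measured value of 4500 nM. Compound 3 `O=C(Nc1ccc(Cl)cc1CN1C(=O)c2ccccc2C1=O)c1ccccc1` likewise reaches only a limit, > 100000 nM. Compound 3 therefore sits at the edge of what this assay can report, and two of the three values shown share that edge (the limit of > 100000 nM in this assay, at which 2 of the 3 values shown sit).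

Compound 4 `O=C(Nc1ccc(Cl)cc1CN1C(=O)c2ccccc2C1=O)c1cccnc1` differs from compound 3 in one place: pyridin-3-yl in place of phenyl on a carbonyl carbon. Among the measured compounds shown here, no measured pair shows this exact swap, so its effect is open. Compound 4 is expected to remain close to the limit, the step from compound 3 being estimated as an at least 1.2-fold lower number from compound 3 to compound 4 (0.09 log units; that floor lies within the scatter). The estimated value for compound 4 is 80000 nM, between 15000 nM and 300000 nM.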

Compound 4, half-maximal effective concentration: 35000 nM
For compound 4 the middle estimate is 2.3-fold (0.36 log units) above the measured one; the measured number falls inside the stated range.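

In this assay, pyridin-3-yl in place of phenyl on a carbonyl carbon gives an at least 2.8-fold lower number from compound 3 to compound 4 (0.45 log units; beyond the scatter). Among the compounds shown here, this shows that the group at this position can move the shared core of compound 3 and compound 4 off the limit of the assay, with a single ring nitrogen as the only change. The step can be stated only as a floor, because the value of compound 3 is a limit and not a number: the limit of > 100000 nM in this assay, at which 2 of the 4 values shown sit.

From the compounds shown here alone, the true size of the step therefore remains open. So does whether pyridin-4-yl or a pyrimidine ring on the same carbonyl carbon would lower the number further.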